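The source may hold more compounds than are shown below. What is called first, only, known or untested is meant among the compounds shown, and "the series" means these compounds.

Measured so far in a functional assay on SW-620 cells (Homo sapiens) for inhibition, read by MTT assay, with a stated time of 72 h; on this read-out higher numbers stand for weaker inhibition and lower numbers for stronger inhibition:
- compound 1 `COc1ccc(CNCc2c(OC)cc(Oc3cccc(Nc4ccccc4)c3)cc2OC)cc1`: 6970 nM
- compound 2 `COc1cc(Oc2cccc(Nc3ccccc3)c2)cc(OC)c1CNCc1ccc(F)cc1`: 6770 nM
- compound 3 `COc1ccc(CCCNCc2c(OC)cc(Oc3cccc(Nc4ccccc4)c3)cc2OC)cc1`: 6400 nM

Compound 3 stands where the other two stand: the steps of a 1.1-fold lower number from compound 1 to compound 3 (0.04 log units; within the scatter) and a 1.1-fold lower number from compound 2 to compound 3 (0.02 log units; within the scatter) both fall within the scatter, so the three numbers are one level, not a ranking. The third member, compound 4 `COc1cc(Oc2cccc(Nc3ccccc3)c2)cc(OC)c1CNCc1ccc(O)cc1`, is yet to be measured in this assay.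

The change from compound 3 to compound 4 is 4-hydroxyphenyl in place of 2-(4-methoxyphenyl)ethyl on a saturated chain carbon bound to an amine nitrogen.

For the measured compounds named here, three measured steps bear on this site. The swap a 1.0-fold lower number from compound 1 to compound 2 (0.01 log units; within the scatter) touched the same aromatic carbon that now receives a hydroxy; the swaps a 1.1-fold lower number from compound 1 to compound 3 (0.04 log units; within the scatter) and a 1.1-fold lower number from compound 2 to compound 3 (0.02 log units; within the scatter) changed the length of the chain and the ring substituent together. None of them moved this assay beyond the scatter. Going by the values given here, no measured compound carries a hydroxy at this position, so the donor that enters is untested; the shared core, the amine and the diaryl ether side are unchanged throughout.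

The step expected is a 1.0-fold higher number from compound 3 to compound 4 (0.01 log units; within the scatter), nothing beyond the scatter, with the untested hydroxy as the only reason for a wide band. Compound 4 is estimated at 6500 nM, between 3000 nM and 14000 nM.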

Compound 4, half-maximal inhibitory concentration: 7940 nM
For compound 4 the middle estimate is 1.2-fold (0.09 log units) below the measured one; measured number inside the range.
By their numbers in this assay, from the lowest: compounds 3, 2, 1 and 4 (each within the scatter of the next).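

In this assay a hydrogen-bond donor on this ring, absent from compound 1, compound 2 and compound 3, leaves the number within the scatter. This holds for hydroxy in place of fluoro on an aromatic carbon (a 1.2-fold higher number from compound 2 to compound 4 (0.07 log units; within the scatter)) and for hydrogen in place of methyl on an oxygen on an aromatic ring (a 1.1-fold higher number from compound 1 to compound 4 (0.06 log units; within the scatter)). The larger exchange, 4-hydroxyphenyl in place of 2-(4-methoxyphenyl)ethyl on a saturated chain carbon bound to an amine nitrogen, alters the chain and the ring substituent together and also stays within the scatter (a 1.2-fold higher number from compound 3 to compound 4 (0.09 log units; within the scatter)), so all four compounds stand at one level, and no evidence on the reason for that level is at hand.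

The compounds shown leave open whether a carboxylic acid or a primary amine in place of the hydroxy, or a longer chain carrying the hydroxy, would move the number beyond the scatter. Also open, from the compounds shown here alone, is whether the level holds with an amide in place of the amine, or with any change to the shared core, which stays the same in all four compounds.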